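Swapping Fluoro for Chloro on the Anilino Ring

A few compounds are considered here, and "the series" means these few. Any claim that something is new, unique, unknown or untested is made for them only; others in the source may bear on it.

In a functional assay on MGC-803 cells (Homo sapiens) for inhibition, read by MTT assay, with a stated time of 72 h (on this read-out higher numbers stand for weaker inhibition and lower numbers for stronger inhibition), compound 3 `C=CC(=O)Nc1cccc(NC(=O)CSc2nc(Nc3ccc(F)cc3)c3ccccc3n2)c1` gives 8290 nM. Among the three measured compounds it stands second highest. Compound 2 `C=CC(=O)Nc1cccc(NC(=O)CSc2nc(Nc3cccc(Cl)c3)c3ccccc3n2)c1` gives 7830 nM, and the two lie within the scatter of each other: a 1.1-fold higher number from compound 2 to compound 3 (0.02 log units; within the scatter). Compound 1 `C=CC(=O)Nc1cccc(NC(=O)CSc2nc(Nc3ccccc3F)c3ccccc3n2)c1` gives 26100 nM, the furthest from compound 3: a 3.1-fold lower number from compound 1 to compound 3 (0.50 log units; beyond the scatter).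

Compound 4 `C=CC(=O)Nc1cccc(NC(=O)CSc2nc(Nc3ccc(Cl)cc3)c3ccccc3n2)c1` differs from compound 3 by chloro in place of fluoro on an aromatic carbon. Going by the values given here, no measured step exchanges the halogen at this position on its own. The nearest comparison, a 1.1-fold higher number from compound 2 to compound 3 (0.02 log units; within the scatter), swaps a chloro for a fluoro while also moving it, and shows nothing beyond the scatter. The larger steps, a 3.3-fold lower number from compound 1 to compound 2 (0.52 log units; beyond the scatter) and a 3.1-fold lower number from compound 1 to compound 3 (0.50 log units; beyond the scatter), concern the replacement of the 2-fluorophenyl of compound 1 rather than the identity of the halogen alone. The account therefore expects a 1.2-fold lower number from compound 3 to compound 4 (0.07 log units; within the scatter), that is, no step beyond the scatter in this assay. Compound 4 is estimated at 7000 nM, with a range from 3500 nM to 16000 nM.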

Compound 4, half-maximal inhibitory concentration: 14300 nM
Compound 4: middle estimate off by 2.0-fold (0.31 log units), on the low side; the measured number falls inside the stated range.
By their numbers in this assay, from the lowest: compounds 2, 3, 4 and 1 (each within the scatter of the next, the first and the last beyond it).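

With the halogen exchanged on its own at this position, para to a large group, the step in this assay is (a 1.7-fold higher number from compound 3 to compound 4 (0.24 log units; within the scatter)), so this single change shows nothing beyond the scatter. Moving the chloro from the 3-chlorophenyl to the 4-chlorophenyl arrangement gives (a 1.8-fold higher number from compound 2 to compound 4 (0.26 log units; within the scatter)), and the change from 2-fluorophenyl to 4-chlorophenyl gives (a 1.8-fold lower number from compound 1 to compound 4 (0.26 log units; within the scatter)), so compound 4 lies within the scatter of all three earlier compounds, although compound 2 and compound 3 lie beyond it from compound 1. No measurement at hand offers a reason for these numbers.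

The compounds shown leave open whether a methoxy, a trifluoromethyl or an amine on this phenyl ring would produce a step beyond the scatter. They also leave open whether exchanging fluoro for chloro would read the same elsewhere on the ring.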